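The source may hold more compounds than are shown below. What is called first, only, known or untested is meant among the compounds shown, and "the series" means these compounds.

Measured compounds:
compound 1, `CCC(C)N(Cc1cccs1)C(=O)COc1ccc(C)cc1` — 2000 nM
compound 2, `CCN(Cc1cccs1)C(=O)COc1ccc(C(C)C)cc1` — 397 nM
compound 3, `CCN(Cc1cccs1)C(=O)COc1ccc2c(c1)CCCC2` — 689 nM

These three share a core and were tested in an assay on HEK293 cells for agonist activity at transient receptor potential cation channel subfamily M member 8 (Homo sapiens), read by fluorescence and calcium flux, with a stated time of 15 min; a higher number here means that more compound is needed for the effect, a lower number that less compound is needed. Compound 1 gives 2000 nM, the highest of the three numbers. The nearest to it is compound 3 at 689 nM, and the furthest is compound 2 at 397 nM; both gaps lie beyond the scatter, so compound 1 needs more compound for its effect than either of the other two. No pair among these three differs in one place only, so no single change can be isolated from the measured set.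

The next compound, compound 4, `Cc1ccc(OCC(=O)N(CCO)Cc2cccs2)cc1`, has not yet been measured. It differs from compound 1 in one place: 2-hydroxyethyl in place of sec-butyl on an amide-type nitrogen.

For the measured compounds named here, nothing among the measured compounds tells how a change at the amide-type nitrogen alone moves the number in this assay. From the compounds shown here alone, compound 1 stands as the weakest measured point, and the move to a 2-hydroxyethyl is untested here. Compound 4 is therefore expected to stay in a similar range, with a step of a 1.5-fold higher number from compound 1 to compound 4 (0.18 log units; within the scatter) from compound 1 that is expected to be small and of uncertain direction, not clearly beyond the scatter. The estimate for compound 4 is 3000 nM, with a range from 800 nM to 12000 nM.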

Compound 4, half-maximal effective concentration: 900 nM
The estimate for compound 4 lay 3.3-fold (0.52 log units) above the measured number; the measured number falls inside the stated range.
By their numbers in this assay, from the lowest: compounds 2, 3 and 4 (each within the scatter of the next, the first and the last beyond it); then compound 1.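

In this assay, for the compounds shown here, 2-hydroxyethyl in place of sec-butyl on an amide-type nitrogen gives a 2.2-fold lower number from compound 1 to compound 4 (0.35 log units; beyond the scatter) and is a modest step, the first change at this position that can be read on its own. It shows that this position responds to the group it carries, and that the number does not rise when an unbranched chain with a hydrogen-bond donor and acceptor replaces a branched chain with neither. The step combines several differences at once, and nothing given here accounts for it or assigns it to any one of them.

An ethyl, a 2-methoxyethyl or a 2-aminoethyl on the same nitrogen, with the rest of compound 1 unchanged, would help separate the role of the hydroxyl hydrogen from that of the oxygen and of the loss of branching, and a 3-hydroxypropyl would test the chain length. From the compounds shown here alone, it also remains open whether the same exchange would move the number similarly with the other aryl groups seen in compound 2 and compound 3.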